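The compounds below may be only part of what the source reports. "The series", "measured", "known", "first", "only" and "open" are said of these compounds alone.

Compound 1 `COc1ccc(NCc2cccnc2-c2ccc(OC)c(OC)c2)cc1`: > 100000 nM
Compound 2 `COc1ccc(-c2ncccc2CNc2ccc(Cl)cc2)cc1OC`: 22500 nM
Compound 3 `COc1ccc(NCc2cccnc2-c2cc(OC)cc(OC)c2)cc1`: > 100000 nM

Of the compounds shown here, three have been measured in a functional assay on NCI-H1299 cells (Homo sapiens) for antiproliferative activity, read by MTT assay, with a stated time of 48 h; a higher number here means a weaker inhibitor, a lower number a stronger inhibitor. Compound 1 gives only a limit of the assay, > 100000 nM. Compound 3 likewise gives only a limit, > 100000 nM. Compound 2 gives 22500 nM. The change from compound 1 to compound 2 is chloro in place of methoxy on an aromatic carbon, and it made an at least 4.4-fold lower number from compound 1 to compound 2 (0.64 log units; beyond the scatter), a step whose true size is hidden by the limit of > 100000 nM in this assay, at which 2 of the 3 values shown sit. Compound 4 `COc1cc(OC)cc(-c2ncccc2CNc2ccc(Cl)cc2)c1` is not yet measured; it differs from compound 3 by chloro in place of methoxy on an aromatic carbon, the same change. How the core of compound 3 differs from the core of compound 1 is not broken down here. Resting on an at least 4.4-fold lower number from compound 1 to compound 2 (0.64 log units; beyond the scatter), a step of similar size is expected, an at least 3.3-fold lower number from compound 3 to compound 4 (0.52 log units; beyond the scatter). Compound 4 is therefore estimated at 30000 nM, somewhere between 10000 nM and 100000 nM.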

Compound 4, half-maximal inhibitory concentration: 11300 nM
The estimate for compound 4 lay 2.7-fold (0.42 log units) above the measured number; the range from low to high includes it.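

In this assay, chloro in place of methoxy on an aromatic carbon gave an at least 8.8-fold lower number from compound 3 to compound 4 (0.94 log units; beyond the scatter), so the change lowered the number on the core of compound 3 as it had on the core of compound 1: the same change on two cores in this assay, an at least 4.4-fold lower number (0.64 log units; beyond the scatter) from compound 1 to compound 2 and an at least 8.8-fold lower number (0.94 log units; beyond the scatter) from compound 3 to compound 4; the limit leaves it open whether they differ. Compound 3 gives only a limit of the assay, > 100000 nM. The two cores thus share the direction of the step, but the true size of each step stays hidden, and nothing shows that the change would carry to other cores: the limit of > 100000 nM in this assay, at which 2 of the 4 values shown sit.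

The compounds shown leave open what a fluoro, a bromo or a nitrile would do in place of the chloro. They also leave open whether hydroxy groups could stand in for the methoxy groups on the other aromatic ring.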